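Ring size and linker on the ring nitrogen of the core

The source may report more compounds than this note shows. Statements on the series, on what has been measured and on what is new or still open speak of the compounds shown alone.

Measured compounds:
compound 1 `CCn1c(-c2ccc(OCc3c(-c4c(Cl)cccc4Cl)noc3C(C)C)cc2)nc2ccc(C(=O)O)cc21` 19.3 nM
compound 2 `CC(C)c1onc(-c2c(Cl)cccc2Cl)c1COc1ccc(-c2nc3ccc(C(=O)O)cc3n2CC2CC2)cc1` 29.1 nM
compound 3 `CC(C)c1onc(-c2c(Cl)cccc2Cl)c1COc1ccc(-c2nc3ccc(C(=O)O)cc3n2C2CCCCCC2)cc1` 113 nM

In an assay on isolated protein for agonist activity at Bile acid receptor (Homo sapiens), read by TR-FRET (on this read-out higher numbers stand for an effect only at larger amounts of compound and lower numbers for an effect already at smaller amounts), compound 3 gives the highest of the three numbers. The step of a 5.9-fold higher number from compound 1 to compound 3 (0.77 log units; beyond the scatter) and the step of a 3.9-fold higher number from compound 2 to compound 3 (0.59 log units; beyond the scatter) both run against it, while the step of a 1.5-fold higher number from compound 1 to compound 2 (0.18 log units; within the scatter) stays within the scatter.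

Compound 4 `CC(C)c1onc(-c2c(Cl)cccc2Cl)c1COc1ccc(-c2nc3ccc(C(=O)O)cc3n2CC2CCCCC2)cc1` is not yet measured. It differs from compound 3 in one place: cyclohexylmethyl in place of cycloheptyl on an aromatic nitrogen. The change keeps the same atoms and ring count on the aromatic nitrogen but puts a six-membered ring on a one-carbon chain instead of a seven-membered ring bound directly.

Among the measured compounds shown here, two measured steps bear on this. The step of a 3.9-fold higher number from compound 2 to compound 3 (0.59 log units; beyond the scatter) shows that moving from a chain-linked ring to a directly bound seven-membered ring raised the number in this assay by a modest amount, and the step of a 5.9-fold higher number from compound 1 to compound 3 (0.77 log units; beyond the scatter) shows a similar rise from the ethyl group. Compound 4 returns to a chain-linked ring, but a larger one than in compound 2. The estimated outcome is therefore a modest drop in the number from compound 3, roughly a 2.1-fold lower number from compound 3 to compound 4 (0.31 log units; beyond the scatter), not reaching compound 2. The estimate for compound 4 in this assay is 55 nM, with a range from 20 nM to 150 nM.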

Compound 4, half-maximal effective concentration: 19.9 nM
The estimate for compound 4 lay 2.8-fold (0.44 log units) above the measured number; measured number below the stated range.
By their numbers in this assay, from the lowest: compounds 1, 4 and 2 (each within the scatter of the next); then compound 3.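

In this assay, the step of a 5.7-fold lower number from compound 3 to compound 4 (0.75 log units; beyond the scatter) joins two groups with the same count of carbon, so at this position on the aromatic nitrogen the outcome depends on how those carbons are arranged and not only on how many there are. On the one-carbon chain, the size of the group made no readable difference: the step of a 1.5-fold lower number from compound 2 to compound 4 (0.17 log units; within the scatter) and the step of a 1.0-fold higher number from compound 1 to compound 4 (0.01 log units; within the scatter) both stay within the scatter, which leaves compound 3, with its seven-membered ring bound directly, as the only one of the four set apart from the others. Nothing measured here gives a reason for this difference.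

Compound 3 is the only compound shown with a ring bound directly to the aromatic nitrogen, so it remains open whether a directly bound cyclohexyl or cyclopentyl would give a number like that of compound 3 or like those of the chain-linked compounds. Also open, going by these compounds, is whether the flat result on the chain would hold with a longer chain between ring and nitrogen, or with an amine such as piperidine in place of the cyclohexyl ring.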